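From methoxycarbonyl to propyl on a carbonyl carbon

The compounds below may be only part of what the source reports. "The series", "measured", "known", "first", "only" and "open" are said of these compounds alone.

Of the compounds shown here, three sharing one core have been measured in a functional assay on B16 cells (Mus musculus) for inhibition; a higher number here means a weaker inhibitor, a lower number a stronger inhibitor. Compound 3 `COC(=O)C(=O)Nc1cccc(C(=O)/C=C/c2ccc(O)c(OC)c2)c1` gives 4.41 ug/mL and compound 1 `COc1cc(/C=C/C(=O)c2cccc(NC(=O)c3cc(Cl)cc(Cl)c3)c2)ccc1O` gives 4.83 ug/mL, two values that cannot be told apart. Compound 2 `COc1cc(/C=C/C(=O)c2cccc(NC(=O)c3ccc(Cl)cc3Cl)c2)ccc1O` gives 12.8 ug/mL, the weaker result, which is a 2.9-fold lower number from compound 2 to compound 3 (0.46 log units; beyond the scatter).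

Compound 4 `CCCC(=O)Nc1cccc(C(=O)/C=C/c2ccc(O)c(OC)c2)c1` differs from compound 3 by propyl in place of methoxycarbonyl on a carbonyl carbon. All three measured steps change the group at this same carbon. There is a 1.1-fold lower number from compound 1 to compound 3 (0.04 log units; within the scatter) and a 2.7-fold higher number from compound 1 to compound 2 (0.42 log units; beyond the scatter), so the exchanges so far range from no real shift to a modest one. Within the data shown here, none of them involves propyl, so the data offer no direct precedent.

A small step in this assay is therefore expected, towards a higher number if it shows at all, and it is estimated as a 1.4-fold higher number from compound 3 to compound 4 (0.13 log units; within the scatter). Compound 4 is expected at about 6 ug/mL, with an estimated range of 2.5 ug/mL to 15 ug/mL.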

Compound 4, half-maximal inhibitory concentration: 1.43 ug/mL
The estimate for compound 4 lay 4.2-fold (0.62 log units) above the measured number; the measured number lies below the stated range.
By their numbers in this assay, from the lowest: compound 4; then compounds 3 and 1 (each within the scatter of the next); then compound 2.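

In this assay, the plain propyl chain on this carbonyl carbon gives the strongest inhibitor of the four, with steps to it from each earlier compound (a 3.1-fold lower number from compound 3 to compound 4 (0.49 log units; beyond the scatter); a 3.4-fold lower number from compound 1 to compound 4 (0.53 log units; beyond the scatter); a 9.0-fold lower number from compound 2 to compound 4 (0.95 log units; beyond the scatter)). The position therefore needs neither a dichlorophenyl ring nor a methoxycarbonyl group for inhibition, and it responds more to this exchange than the matching values of compound 1 and compound 3 alone could show. No measurement at hand explains why propyl does better than these groups.

From the compounds shown here alone, it remains open whether a shorter chain such as methyl or a longer one such as pentyl would lower the number further. Going by these compounds, it is equally open whether a chain carrying an amine or a carboxylic acid would keep the inhibition seen with propyl.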